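Replacing the methoxy of compound 2 with hydrogen

The compounds below may be only part of what the source reports. "The series", "measured", "known", "first", "only" and "open" are said of these compounds alone.

Measured in a functional assay on HeLa cells (Homo sapiens) for inhibition, read by MTT assay, with a stated time of 72 h; a lower number here means a stronger inhibitor, a higher number a weaker inhibitor
compound 1 `COc1cc(OC)c(OC)cc1/C=C/C(=O)c1ccc(Cl)cc1` gives 36500 nM
compound 2 `COc1ccc(C(=O)/C=C/c2cc(OC)c(OC)cc2OC)cc1` gives 37600 nM
compound 3 `COc1cc(OC)c(-c2cc(=O)c3ccc(O)cc3o2)cc1OC` gives > 150000 nM (a limit, not a number)

Compound 2 gives 37600 nM in this assay and sits within the scatter of compound 1, its nearest neighbour on the numbers. Compound 3 reaches only a limit of the assay, (the limit of > 150000 nM in this assay, at which 1 of the 3 values shown sits). Going by the values given here, that limit gives no number to compare with the other two compounds, and no single-place step joins compound 3 to them.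

The next compound to be measured is compound 4 `COc1cc(OC)c(OC)cc1/C=C/C(=O)c1ccccc1`. It carries hydrogen in place of methoxy on an aromatic carbon, para to a large group (hydrogen in place of methoxy on an aromatic carbon). The cut one bond further out reads 4-methoxyphenyl to phenyl.

Among the compounds with values here, one measured step bears on this change, methoxy in place of chloro on an aromatic carbon, and it amounts to a 1.0-fold higher number from compound 1 to compound 2 (0.01 log units; within the scatter). This is a single step, so the support is thin, but it gives no reason to expect a change beyond the scatter in this assay, and no direction can be argued from it.

The expected step is a 1.0-fold higher number from compound 2 to compound 4 (0.00 log units; within the scatter).

For compound 4 the estimated value is 38000 nM, with an expected range of 17000 nM to 85000 nM.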

Compound 4, half-maximal inhibitory concentration: > 150000 nM
Compound 4: a limit, no number; the forecaster's own chance of this, stated with the estimate: 8%; middle value at least 3.9-fold (0.59 log units) away from the limit.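

In this assay compound 4 gives > 150000 nM, which is a limit of the assay and not a number: the limit of > 150000 nM in this assay, at which 2 of the 4 values shown sit.

The earlier pair showed only that methoxy and chloro at this place, para to a large group, read alike, with a 1.0-fold higher number from compound 1 to compound 2 (0.01 log units; within the scatter). Hydrogen at the same place separates clearly from both, with an at least 3.9-fold higher number from compound 2 to compound 4 (0.60 log units; beyond the scatter) and an at least 4.1-fold higher number from compound 1 to compound 4 (0.61 log units; beyond the scatter), so within these three compounds, which differ only here, a substituent at this place goes with a measurable number, and its absence does not.

Going by these compounds, the true size of the loss remains unknown, as both steps give only a lower bound. Also open, on these data alone, is whether a small group such as fluoro, or an amine or a carboxylic acid, at this place would stay with compound 1 and compound 2 or fall away with compound 4, and so whether the two matching groups reflect a wider tolerance at this place or only a coincidence of the pair.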